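Vero cytotoxicity notes: chloro addition on a shared core

A few compounds are considered here, and "the series" means these few. Any claim that something is new, unique, unknown or untested is made for them only; others in the source may bear on it.

Compound 1 `O=[N+]([O-])c1ccccc1-c1nnc(-c2ccc(-n3cccc3)cc2)o1`: 266000 nM
Compound 2 `CC(=O)N1N=C(c2ccc(-n3c(C)ccc3C)cc2)OC1c1ccccc1Cl`: 201000 nM
Compound 3 `Cc1ccc(C)n1-c1ccc(C(=O)N/N=C/c2ccc(O)cc2)cc1`: "not determined" (no result reported)

In an ADME assay on Vero cells (Chlorocebus sabaeus) for cytotoxicity, read by MTT assay, with a stated time of 72 h (on this read-out higher numbers stand for weaker inhibition and lower numbers for stronger inhibition), compound 2 gives 201000 nM and compound 1 gives 266000 nM; the gap between them lies within the scatter, so the two stand level on the numbers shown. Among the measured compounds shown here, compound 3 carries no result, leaving only two numbers to work from. Compound 4 `CC(=O)N1N=C(c2ccc(-n3c(C)ccc3C)cc2)OC1c1c(Cl)cccc1Cl` differs from compound 2 by chloro in place of hydrogen on an aromatic carbon. For the measured compounds named here, no step between measured compounds is available, so any expectation rests on compound 2 alone and on the small size of the change. The expected step is a 1.1-fold lower number from compound 2 to compound 4 (0.05 log units; within the scatter), none beyond the scatter in either direction. Compound 4 is estimated at 180000 nM, with a range from 90000 nM to 360000 nM.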

Compound 4, half-maximal inhibitory concentration: 221000 nM
Beside the measured number, compound 4's estimate is 1.2-fold (0.09 log units) below it; low and high end bracket the measured number.
By their numbers in this assay, from the lowest: compounds 2, 4 and 1 (each within the scatter of the next).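

In this assay, the change from 2-chlorophenyl to 2,6-dichlorophenyl gives a 1.1-fold higher number from compound 2 to compound 4 (0.04 log units; within the scatter) and so shows that chloro in place of hydrogen, ortho to a large group, leaves compound 4 level with compound 2 on the numbers shown. This single step offers no sign that this position responds to chloro, and no measurement on hand explains the result.

Still open, going by these compounds, is whether an amine, a carboxylic acid or a longer chain on this aromatic carbon would give a step beyond the scatter. On these data alone, whether chloro would behave alike on the core of compound 1 also remains open.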